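Fluoro in Place of Chloro: From Compound 1 to Compound 4

A few compounds are considered here, and "the series" means these few. Any claim that something is new, unique, unknown or untested is made for them only; others in the source may bear on it.

Compound 1 `CCC1(CCCCN2CCN(c3ccc(Cl)cc3)CC2)C(=O)Nc2ccccc21` was tested in a functional assay on the whole organism (strain NMRI) with Mus musculus as the target, with a stated time of 5 min; on this read-out lower numbers stand for an effect already at smaller amounts and higher numbers for an effect only at larger amounts of compound. In this assay compound 1 gives > 10 mg/kg, which is a limit of the assay and not a number. Compound 3 `CCC1(CCCCN2CCN(c3ccc(Cl)cc3)CC2)C(=O)Nc2cc(F)ccc21` carries fluoro in place of hydrogen on an aromatic carbon of the shared core, and in this assay compound 3 gives > 10 mg/kg, again a limit. The step that the two limits leave unreadable from compound 1 to compound 3 is therefore not readable. Compound 2 `CCC1(CCCCN2CCC(C)CC2)C(=O)Nc2ccccc21` has in this assay "not determined" (no result reported). Compound 4 `CCC1(CCCCN2CCN(c3ccc(F)cc3)CC2)C(=O)Nc2ccccc21` differs from compound 1 by fluoro in place of chloro on an aromatic carbon. Among the measured compounds shown here, no measured step bears on this change; the only evidence is the limit of > 10 mg/kg in this assay, at which 2 of the 3 values shown sit. The step that the limit leaves unreadable from compound 1 to compound 4 is expected to be small. Compound 4 is estimated at 15 mg/kg, within 5 mg/kg to 40 mg/kg.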

Compound 4, minimum effective dose: < 1 mg/kg
Compound 4 ended at the assay's limit; the forecaster's own chance of this, stated with the estimate: 70%; at least 15-fold (1.17 log units) between middle value and limit.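

In this assay, replacing 4-chlorophenyl with 4-fluorophenyl gives an at least 10-fold lower number from compound 1 to compound 4 (1.00 log units; beyond the scatter), which shows that the read-out responds to the halogen at this place, para to a large group. Going by these compounds, compound 4 gives < 1 mg/kg, which is a limit of the assay and not a number, so the full size of the step stays unknown. The earlier steps could not be read, which makes this the first readable change among the compounds shown.

Still open, on these data alone, is how far compound 4 lies past its limit. The compounds shown also leave open whether hydrogen, methoxy or trifluoromethyl at this place would behave like fluoro or like chloro.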